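The source may hold more compounds than are shown below. What is called first, only, known or untested is meant among the compounds shown, and "the series" means these compounds.

In a functional assay on HEK293 cells for agonist activity at D(4) dopamine receptor (Homo sapiens), read by FLIPR (a higher number here means that more compound is needed for the effect, a lower number that less compound is needed), the three measured compounds give the following numbers:

Compound 1 `Cc1cccc(NC(=O)CN2CCC(c3cccc(C#N)n3)CC2)c1`: 36 nM
Compound 2 `O=C(NCN1CCC(c2cccc[n+]2[O-])CC1)c1ccc2ccccc2c1`: 115 nM
Compound 3 `O=C(CN1CCC(c2cccc[n+]2[O-])CC1)Nc1ccc(F)cc1C(F)(F)F`: 473 nM

Compound 1 stands at the lowest number of the three, so it needs the least material for the effect. Compound 2 lies next to it, at a number that is higher by more than the usual scatter, and compound 3 lies furthest away, again beyond the scatter. Compound 4 `COc1ccccc1C1CCN(CC(=O)Nc2cccc(C)c2)CC1` has not yet been measured. It keeps the core of compound 1 and differs from it in one place (2-methoxyphenyl in place of 6-cyanopyridin-2-yl on a saturated ring carbon). The group that leaves carries a nitrile and a ring nitrogen; the group that enters carries a methoxy on a carbon-only ring. Among the measured compounds shown here, no pair of measured compounds differing in just one place is available, so the size of this step cannot be read from the data. A small shift toward a higher number is expected, one that may well stay within the scatter, giving an estimated step of a 1.7-fold higher number from compound 1 to compound 4 (0.22 log units; within the scatter). For compound 4 the expected value in this assay is 60 nM, with a likely range from 15 nM to 250 nM.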

Compound 4, half-maximal effective concentration: 420 nM
Estimate against measurement, compound 4: 7.0-fold (0.85 log units) below; the whole stated range lies below it.
By their numbers in this assay, from the lowest: compound 1; then compound 2; then compounds 4 and 3 (each within the scatter of the next).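

In this assay, the group on the saturated ring carbon turns out to matter a great deal: with the rest of compound 1 unchanged, 2-methoxyphenyl in place of 6-cyanopyridin-2-yl gives a 12-fold higher number from compound 1 to compound 4 (1.07 log units; beyond the scatter). The two groups have the same count of heavy atoms and each holds one six-membered aromatic ring, so a step of this size can arise from a swap that leaves those counts alike. Nothing available here accounts for the size of this step.

Which part of the change carries the step stays open, as the nitrile, the ring nitrogen and the methoxy all change together in this one swap. A pyridin-2-yl without the nitrile, or a plain phenyl, at the same place would help to tell these parts apart.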